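Benzyloxy aryl swap on the shared core

A few compounds are considered here, and "the series" means these few. Any claim that something is new, unique, unknown or untested is made for them only; others in the source may bear on it.

For the measured compounds named here, compound 1 `Cc1cc(C)cc(COc2ccc(-c3cc(CN4CCN(Cc5ccc(C(F)(F)F)cc5)CC4)no3)cc2)c1` gives 1600 nM in a functional assay on MCF7 cells (Homo sapiens) for antiproliferative activity, read by sulforhodamine B assay, with a stated time of 72 h (a lower number here means a stronger inhibitor, a higher number a weaker inhibitor), the highest of the two numbers measured so far, while compound 2 `N#Cc1ccc(COc2ccc(-c3cc(CN4CCN(Cc5ccc(C(F)(F)F)cc5)CC4)no3)cc2)cc1` gives 100 nM. Going by the values given here, the only measured step, a 16-fold lower number from compound 1 to compound 2 (1.20 log units; beyond the scatter), shows that exchanging the 3,5-dimethylphenyl for a 4-cyanophenyl on a saturated chain carbon bound to an oxygen on an aromatic ring brings a large drop in the number. Compound 3 `COc1ccc(COc2ccc(-c3cc(CN4CCN(Cc5ccc(C(F)(F)F)cc5)CC4)no3)cc2)cc1` is not yet measured; it differs from compound 1 by 4-methoxyphenyl in place of 3,5-dimethylphenyl on a saturated chain carbon bound to an oxygen on an aromatic ring. Among the compounds with values here, the change sits at the same place as the measured step but brings in a different group, so that step bears on it by place only, and no measured pair shows a methoxy-bearing ring here. Compound 3 is expected to give a lower number, by a smaller step, namely a 3.2-fold lower number from compound 1 to compound 3 (0.51 log units; beyond the scatter). In this assay compound 3 is estimated at 500 nM, within a range of 150 nM to 1600 nM.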

Compound 3, half-maximal inhibitory concentration: 1300 nM
Estimate against measurement, compound 3: 2.6-fold (0.41 log units) below; measured number inside the range.
By their numbers in this assay, from the lowest: compound 2; then compounds 3 and 1 (each within the scatter of the next).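

In this assay, a 1.2-fold lower number from compound 1 to compound 3 (0.09 log units; within the scatter) leaves 4-methoxyphenyl and 3,5-dimethylphenyl indistinguishable on a saturated chain carbon bound to an oxygen on an aromatic ring, so replacing the 3,5-dimethylphenyl does not by itself lower the number. With a 13-fold higher number from compound 2 to compound 3 (1.11 log units; beyond the scatter), methoxy in place of cyano on an aromatic carbon accounts for a large step, and among these three compounds the low number appears only with the cyano group, while compound 3 goes against any reading that credits the removal of 3,5-dimethylphenyl alone. Nothing available explains the gap between the cyano and methoxy compounds.

As far as these compounds go, whether the low number is specific to the nitrile remains open, since a carboxylic acid, an amine or a chlorine on the same ring could separate it from other groups. From the compounds shown here alone, it is also open whether a longer chain between the ring and the oxygen would keep the number of compound 2.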